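Swapping Dimethylamino for Methoxy on a Carbonyl Carbon

This account rests on a few compounds, and the source may have more. Where it says the series, first, only, none or still open, it means among the compounds named here.

Of the compounds shown here, two have been measured so far in a physicochemical assay for lipophilicity, using the shake flask method, at pH 7.4; a higher number here means a more lipophilic compound, a lower number a more polar compound. Compound 1 `CN(C)[C@H]1CC[C@H](Nc2ncnc3sccc23)CC1` gives 0.1, while compound 2 `CN(C)C(=O)N1CCN([C@H]2CC[C@H](Nc3ncnc4[nH]cc(C5CCOCC5)c34)CC2)CC1` gives 1.5. Compound 2 therefore holds the higher of the two numbers, and the gap between them lies beyond the usual scatter of repeated measurements. These two compounds differ in several places, so their gap says little about any single change.

Compound 3 `COC(=O)N1CCN([C@H]2CC[C@H](Nc3ncnc4[nH]cc(C5CCOCC5)c34)CC2)CC1` differs from compound 2 in only one place: methoxy in place of dimethylamino on a carbonyl carbon. Put simply, methoxy stands in place of dimethylamino on a carbonyl carbon. Going by the values given here, no measured pair of compounds shows this swap, so the expectation starts from compound 2 at 1.5 and rests on the structural change alone. A small upward step in this assay, just beyond the scatter, is expected: a number 0.40 log units higher from compound 2 to compound 3 (beyond the scatter). For compound 3 the estimate is 1.9, with an estimated range from 1.5 to 2.3.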

Compound 3, distribution coefficient: 2
Compound 3: the middle estimate sits 0.10 log units below what was measured; the range from low to high includes it.
By their numbers in this assay, from the lowest: compound 1; then compound 2; then compound 3.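

Going by these compounds alone, this is the first pair in the set that differs in one place, so a single change can now be read alone: in this assay, methoxy in place of dimethylamino on a carbonyl carbon gives a number 0.50 log units higher from compound 2 to compound 3 (beyond the scatter) in a pair sharing everything else. The step is modest but lies beyond the usual scatter, so a swap at this carbonyl carbon, whose other neighbour is an amide-type nitrogen in a ring, can move this number measurably. Nothing available here explains the direction or size of the step.

Within the data shown here, this swap appears in only one pair, so whether the step would repeat on another core remains open. Also open, going by these compounds, is how a longer chain such as ethoxy, or a ring amine such as pyrrolidine, would compare at the same carbonyl carbon.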